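A Difluorinated Analogue Against a Single Limit

The source may report more compounds than this note shows. Statements on the series, on what has been measured and on what is new or still open speak of the compounds shown alone.

Three compounds sharing one core were taken into a functional assay on G-361 cells (Homo sapiens) for antiproliferative activity, with a stated time of 72 h; on this read-out lower numbers stand for stronger inhibition and higher numbers for weaker inhibition. Compound 1 `OC[C@H]1O[C@@H](n2cnc3c(NCc4cccc(Br)c4)ncnc32)[C@H](O)[C@@H]1O` reads > 166000 nM, and this is a limit of the assay, not a number. The entry for compound 2 `COc1cccc(CNc2ncnc3c2ncn3[C@@H]2O[C@H](CO)[C@@H](O)[C@H]2O)c1` reads "not determined" (no result reported). As far as these compounds go, the entry for compound 3 `COc1ccc(CNc2ncnc3c2ncn3[C@@H]2O[C@H](CO)[C@@H](O)[C@H]2O)c(OC)c1` reads "not determined" (no result reported), so compound 3 stands without a number of its own, and its place on the scale is unknown.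

Compound 4 `OC[C@H]1O[C@@H](n2cnc3c(NCc4ccc(F)cc4F)ncnc32)[C@H](O)[C@@H]1O` has yet to be measured in this assay. It carries 2,4-difluorophenyl in place of 2,4-dimethoxyphenyl on a saturated chain carbon bound to a nitrogen on an aromatic ring.

Going by the values given here, no measured step shows what such a swap does, and the only guide is the limit of compound 1. Weak inhibition is therefore expected, with no step beyond the usual scatter from that limit, though a modest shift towards stronger inhibition remains possible. For compound 4 the estimated value is 100000 nM, with an expected range from 15000 nM to 166000 nM.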

Compound 4, half-maximal inhibitory concentration: > 166000 nM
Compound 4: no number, only a limit (the forecaster's own chance of this, stated with the estimate: 55%); middle value at least 1.6-fold (0.22 log units) from the limit.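

In this assay compound 4 gives > 166000 nM, which is a limit and not a number. Compound 1 gives > 166000 nM, also a limit, so no step can be read between compound 1 and compound 4. The compounds shown leave open what any of these groups does to the read-out, and where compound 2 and compound 3 stand.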